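The source may report more compounds than this note shows. Statements on the series, on what has been measured and on what is new or still open speak of the compounds shown alone.

The study examines a set of anilinopyrimidines in a functional assay for inhibition, with Homo sapiens as the target; on this read-out lower numbers stand for stronger inhibition and higher numbers for weaker inhibition. Compound 1 `Cc1cc(C)cc(Nc2nccc(-c3ccccn3)n2)c1` gives 100 nM, and compound 2 `c1cc(Nc2nccc(-c3ccncc3)n2)cc(OCCn2ccnc2)c1` gives 200 nM in this assay. Compound 3 `Fc1cccc(Nc2nccc(-c3ccccn3)n2)c1` gives 1000 nM, the highest of the three numbers, and its gaps to compound 2 and to compound 1 both lie beyond the scatter, so compound 3 is the weakest inhibitor measured here. Compound 4 `c1ccc(-c2ccnc(Nc3cccc(OCCn4ccnc4)c3)n2)nc1` differs from compound 3 in one place: 2-(1H-imidazol-1-yl)ethoxy in place of fluoro on an aromatic carbon. Going by the values given here, no measured pair shows this exact change, but compound 2 carries the same 2-(1H-imidazol-1-yl)ethoxy group on a related core and gives 200 nM. A step toward a lower number is therefore expected, of the size a 4.0-fold lower number from compound 3 to compound 4 (0.60 log units; beyond the scatter). For compound 4 the estimated value in this assay is 250 nM, in the range 80 nM to 800 nM.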

Compound 4, half-maximal inhibitory concentration: 400 nM
Compound 4: the middle estimate sits 1.6-fold (0.20 log units) below what was measured, within the range that was stated.
By their numbers in this assay, from the lowest: compounds 1, 2 and 4 (each within the scatter of the next, the first and the last beyond it); then compound 3.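

In this assay, 2-(1H-imidazol-1-yl)ethoxy in place of fluoro on this aromatic carbon gives a 2.5-fold lower number from compound 3 to compound 4 (0.40 log units; beyond the scatter) and so shows that the position accepts this much larger group, with a modest gain. Pyridin-2-yl in place of pyridin-4-yl gives a 2.0-fold higher number from compound 2 to compound 4 (0.30 log units; within the scatter) with that side chain in place, so these compounds do not separate the two pyridines. No measurement shown here accounts for either step. Open, going by these compounds, is whether a longer chain or an amine in place of the imidazole would serve equally at this position, and how pyridin-3-yl would compare.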